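Two Cyclic Sulfonates and a Benzyl Ether Yet to Test

The compounds below may be only part of what the source reports. "The series", "measured", "known", "first", "only" and "open" are said of these compounds alone.

Compound 1: `CCC1(Cc2ccccc2)OS(=O)(=O)C=C1OCC(=O)OC` — > 200000 nM
Compound 2: `CCC1(Cc2ccccc2)OS(=O)(=O)C=C1OS(=O)(=O)c1ccc(C)cc1` — 109000 nM

Both measured compounds share one core and differ only in the group hanging from the oxygen on the unsaturated carbon. They were tested in an ADME assay on HEL cells (Homo sapiens) for cytotoxicity, with a stated time of 3 days; on this read-out lower numbers stand for higher toxicity in this test and higher numbers for lower toxicity in this test. In this assay compound 1 gives > 200000 nM, which is a limit of the assay rather than a measured number (the limit of > 200000 nM in this assay, at which 1 of the 2 values shown sits). In this assay compound 2 gives 109000 nM. So compound 1 stands at the limit, and only compound 2 provides an actual number among the two.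

Compound 3, `CCC1(Cc2ccccc2)OS(=O)(=O)C=C1OCc1ccccc1Cl`, is not yet measured. It differs from compound 1 by 2-chlorophenyl in place of methoxycarbonyl on a saturated chain carbon bound to an oxygen on an unsaturated carbon. Within the data shown here, no step between measured compounds shows what such a change does here. The expected step of an at least 2.0-fold lower number from compound 1 to compound 3 (0.30 log units; that floor lies within the scatter) is a modest move toward higher toxicity, not clearly beyond the scatter, and the estimate for compound 3 is 100000 nM, in the range 30000 nM to 250000 nM.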

Compound 3, half-maximal cytotoxic concentration: 38000 nM
The estimate for compound 3 lay 2.6-fold (0.42 log units) above the measured number; the measured number falls inside the stated range.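

Among these compounds, until this result, no step at this position could be read, so nothing tied the group on the saturated chain carbon bound to an oxygen on an unsaturated carbon to any change in the number. Putting 2-chlorophenyl in place of methoxycarbonyl there, which cut one bond further out reads as (methoxycarbonyl)methyl to 2-chlorobenzyl, gives an at least 5.2-fold lower number from compound 1 to compound 3 (0.72 log units; beyond the scatter) in this assay, so this position does respond, and the move is toward higher toxicity in this test. That step is a floor and not an exact size, and the reason lies with compound 1, whose value is a limit of the assay: the limit of > 200000 nM in this assay, at which 1 of the 3 values shown sits.

The change brings in the aromatic ring and the chlorine together, and the compounds shown leave open which of the two carries the step; a plain benzyl group at this place would separate them. Also open, on these data alone, is how a carboxylic acid or an amine on the same chain would read in this assay.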